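A few compounds are considered here, and "the series" means these few. Any claim that something is new, unique, unknown or untested is made for them only; others in the source may bear on it.

Of the compounds shown here, three sharing one core have been measured in an ADME assay on BaF3 cells (Mus musculus) for antiproliferative activity, read by CCK-8 assay, with a stated time of 72 h; a higher number here means a weaker inhibitor of growth, a lower number a stronger inhibitor of growth. Compound 1 `CN1CCN(Cc2ccc(NC(=O)CCSc3ccc4c(/C=C/c5ccccn5)n[nH]c4c3)cc2C(F)(F)F)CC1` gives 2480 nM, compound 2 `CN1CCN(Cc2ccc(NC(=O)CCSc3ccc4c(-c5ccccc5)n[nH]c4c3)cc2C(F)(F)F)CC1` gives 600 nM, and compound 3 `CN1CCN(Cc2ccc(NC(=O)CCSc3ccc4c(-c5ccncc5)n[nH]c4c3)cc2C(F)(F)F)CC1` gives 1060 nM. Compound 3 cannot be separated from compound 2, and both lie below compound 1. The two steps that place it are a 1.8-fold higher number from compound 2 to compound 3 (0.25 log units; within the scatter) and a 2.3-fold lower number from compound 1 to compound 3 (0.37 log units; beyond the scatter).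

The next compound is compound 4 `Cc1ccc(-c2n[nH]c3cc(SCCC(=O)Nc4ccc(CN5CCN(C)CC5)c(C(F)(F)F)c4)ccc23)cn1`, still unmeasured in this assay. The change is 6-methylpyridin-3-yl in place of pyridin-4-yl on an aromatic carbon.

Among the compounds with values here, the closest precedent is the exchange of one six-membered aromatic ring for another at this place, seen in a 1.8-fold higher number from compound 2 to compound 3 (0.25 log units; within the scatter), which stays within the scatter. The larger steps, a 4.1-fold lower number from compound 1 to compound 2 (0.62 log units; beyond the scatter) and a 2.3-fold lower number from compound 1 to compound 3 (0.37 log units; beyond the scatter), remove the 2-(pyridin-2-yl)ethenyl group and so bear on this change only weakly. Within the data shown here, no measured compound carries a methyl on this ring, so that part of the change is untested.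

With compound 2 at 600 nM and compound 3 at 1060 nM as guides, no shift beyond the scatter is expected. The expected step is a 1.2-fold lower number from compound 3 to compound 4 (0.07 log units; within the scatter). The estimate for compound 4 is 900 nM, with an expected range from 350 nM to 2300 nM.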

Compound 4, concentration for 50% growth inhibition: 1180 nM
Estimate against measurement, compound 4: 1.3-fold (0.12 log units) below; measured number inside the range.
By their numbers in this assay, from the lowest: compounds 2, 3 and 4 (each within the scatter of the next); then compound 1.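

Replacing pyridin-4-yl with 6-methylpyridin-3-yl on the aromatic carbon of the five-membered ring brings a 1.1-fold higher number from compound 3 to compound 4 (0.05 log units; within the scatter) in this assay, and a 2.0-fold higher number from compound 2 to compound 4 (0.29 log units; within the scatter) also lies within the scatter, so phenyl, pyridin-4-yl and 6-methylpyridin-3-yl cannot be separated at this position and a methyl-bearing ring now has a measured place among them. The result also extends the earlier contrast with the 2-(pyridin-2-yl)ethenyl group to a third directly attached six-membered ring, with a 2.1-fold lower number from compound 1 to compound 4 (0.32 log units; beyond the scatter), a modest step but one beyond the scatter. No measurement is available that would explain why this exchange leaves the number within the scatter.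

The step to compound 4 alters the ring's point of attachment and adds the methyl in one exchange, so the share of each remains unresolved, and a plain pyridin-3-yl group would be needed to separate them. Also open, from the compounds shown here alone, is whether a primary amine or a carboxylic acid on this ring, or a longer alkyl chain in place of the methyl, would shift the number in this assay beyond the scatter.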